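The source may hold more compounds than are shown below. What is called first, only, known or untested is meant among the compounds shown, and "the series" means these compounds.

Three compounds sharing one core were measured in a functional assay on HT cells (Homo sapiens) for antiproliferative activity, read by fluorescence, with a stated time of 72 h; a lower number here means a stronger inhibitor of growth, a higher number a weaker inhibitor of growth. Compound 1 `CCC(O)CSc1nc(NCc2ccc(-c3ccccn3)cc2)c2[nH]nc(C(C)C)c2n1` gives 273 nM, compound 2 `CC(C)c1n[nH]c2c(NCc3ccc(-c4ccccn4)cc3)nc(SCC3CNC(=O)O3)nc12` gives 80 nM, and compound 3 `CC(C)c1n[nH]c2c(NCc3ccc(-c4ccccn4)cc3)nc(SC(C)C(C)O)nc12` gives 190 nM. Compound 3 stands second highest of the three: it lies within the scatter of compound 1, with a 1.4-fold lower number from compound 1 to compound 3 (0.16 log units; within the scatter), while a 2.4-fold higher number from compound 2 to compound 3 (0.38 log units; beyond the scatter). Compound 4 `CNCCSc1nc(NCc2ccc(-c3ccccn3)cc2)c2[nH]nc(C(C)C)c2n1` differs from compound 3 at the sulfur: 2-(methylamino)ethyl in place of 2-hydroxy-1-methylpropyl on a sulfur. Within the data shown here, the steps that bear on this are the earlier changes at the sulfur, a 3.4-fold lower number from compound 1 to compound 2 (0.53 log units; beyond the scatter) and a 2.4-fold higher number from compound 2 to compound 3 (0.38 log units; beyond the scatter), alongside a 1.4-fold lower number from compound 1 to compound 3 (0.16 log units; within the scatter). Changes here have moved the number only modestly, so a small step is expected, with no firm direction, a 1.1-fold higher number from compound 3 to compound 4 (0.02 log units; within the scatter). Compound 4 is thus estimated at 200 nM, within a range of 70 nM to 550 nM.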

Compound 4, concentration for 50% growth inhibition: 56 nM
For compound 4 the middle estimate is 3.6-fold (0.55 log units) above the measured one; measured number outside the range, below it.
By their numbers in this assay, from the lowest: compounds 4 and 2 (each within the scatter of the next); then compounds 3 and 1 (each within the scatter of the next).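

In this assay the move to 2-(methylamino)ethyl on the sulfur gives a 3.4-fold lower number from compound 3 to compound 4 (0.53 log units; beyond the scatter) and a 4.9-fold lower number from compound 1 to compound 4 (0.69 log units; beyond the scatter) and so shows a chain without a ring moving the number beyond the scatter from both hydroxyl chains. The remaining step, a 1.4-fold lower number from compound 2 to compound 4 (0.15 log units; within the scatter), lies within the scatter, so at this place the 2-oxo-1,3-oxazolidin-5-yl ring of compound 2 is not needed to reach this level. No evidence here accounts for the change.

Open, as far as these compounds go, is whether a primary amine, a dimethylamino group or a longer chain on the sulfur would hold this level, and whether the nitrogen or the loss of the branching carries the step.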